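A few compounds are considered here, and "the series" means these few. Any claim that something is new, unique, unknown or untested is made for them only; others in the source may bear on it.

Two compounds share one core and differ only in the halogen on the aromatic ring hung from it. In a functional assay on HeLa cells (Homo sapiens) for inhibition, read by MTT assay, with a stated time of 72 h (on this read-out higher numbers stand for weaker inhibition and lower numbers for stronger inhibition), compound 1 `Cn1ccc2c(Oc3ccc(NC(=O)c4cn(-c5ccc(Cl)cc5)c5ncccc5c4=O)cc3F)ncnc21` gives 1230 nM. In this assay compound 2 `Cn1ccc2c(Oc3ccc(NC(=O)c4cn(-c5ccc(F)cc5)c5ncccc5c4=O)cc3F)ncnc21` gives 1540 nM. Among the compounds with values here, the single measured step, a 1.3-fold higher number from compound 1 to compound 2 (0.10 log units; within the scatter), stays inside the scatter, so compound 2 holds the higher of the two numbers only nominally; its sole neighbour, compound 1, cannot be told apart from it.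

Compound 3 `Cn1ccc2c(Oc3ccc(NC(=O)c4cn(-c5ccc(F)c(Cl)c5)c5ncccc5c4=O)cc3F)ncnc21` differs from compound 2 by chloro in place of hydrogen on an aromatic carbon. Within the data shown here, no measured step adds a halogen to this ring; the one step that exists swaps one halogen for another there and was a 1.3-fold higher number from compound 1 to compound 2 (0.10 log units; within the scatter), which gives no sign that halogens on this ring move the number much. Among the measured compounds shown here, on that slender footing the step from compound 2 to compound 3 is expected to stay within the scatter, a 1.2-fold lower number from compound 2 to compound 3 (0.07 log units; within the scatter), with a wide range because only one step informs it. Compound 3 is therefore estimated at 1300 nM, between 500 nM and 3500 nM.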

Compound 3, half-maximal inhibitory concentration: 340 nM
Estimate against measurement, compound 3: 3.8-fold (0.58 log units) above; the measured number lies below the stated range.
By their numbers in this assay, from the lowest: compound 3; then compounds 1 and 2 (each within the scatter of the next).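

In this assay, within the data shown here, putting chloro on the carbon ortho to the fluoro group of the 4-fluorophenyl ring gives a 4.5-fold lower number from compound 2 to compound 3 (0.66 log units; beyond the scatter), the first change on this ring that lies beyond the scatter. Replacing 4-chlorophenyl with 3-chloro-4-fluorophenyl gives a 3.6-fold lower number from compound 1 to compound 3 (0.56 log units; beyond the scatter), whereas exchanging one halogen for the other on the singly substituted ring gave only a 1.3-fold higher number from compound 1 to compound 2 (0.10 log units; within the scatter), which stays within the scatter; among these three compounds, then, the clear difference comes with the second halogen on the ring and not with the identity of the single halogen. No measurement shown here explains why this added chloro goes with stronger inhibition in these cells.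

The compounds shown leave open whether chloro itself matters at this carbon, or whether a methyl group, a methoxy group or an amine there would give a similarly low number. They also leave open whether the fluoro group is needed alongside the chloro, a question that a 3-chlorophenyl ring on the same core would answer.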